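This account rests on a few compounds, and the source may have more. Where it says the series, first, only, none or still open, it means among the compounds named here.

Going by the values given here, the two compounds measured so far share one core, and neither of them yields a number in a functional assay on cells for agonist activity at C-X-C chemokine receptor type 4 (Homo sapiens), read by fluorescence and calcium flux, with a stated time of 90 s; on this read-out higher numbers stand for an effect only at larger amounts of compound and lower numbers for an effect already at smaller amounts. Compound 1 `O=S1(=O)CCC(CNCCCCN(C[C@H]2Cc3ccccc3CN2)[C@H]2CCCc3cccnc32)CC1` reaches only the limit of the assay, > 30000 nM. Compound 2 `c1ccc2c(c1)CN[C@@H](CN(CCCCNC1CCNCC1)[C@H]1CCCc3cccnc31)C2` also reaches only the limit of the assay, > 30000 nM. Among the compounds with values here, the single step between them, a step that the two limits leave unreadable from compound 1 to compound 2, thus cannot be sized in either direction; what the data hold is the limit of > 30000 nM in this assay, at which 2 of the 2 values shown sit.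

Compound 3 `c1ccc2c(c1)CN[C@@H](CN(CCCCNC1CCSCC1)[C@H]1CCCc3cccnc31)C2` differs from compound 2 in one place: thian-4-yl in place of piperidin-4-yl on an amine nitrogen. Within the data shown here, no measured step bears on this particular change, and the one step that is recorded lies between two limits, so it offers no size to carry over. All that the numbers say is that compound 2 stands at the limit in this assay.

On that footing compound 3 is expected to sit at the same limit, with an estimate of 30000 nM in this assay, the plausible range running from 5000 nM to 100000 nM. This amounts to an expected step of a number no higher from compound 2 to compound 3 (the limit leaves the size open), that is, no change beyond the scatter, with the most likely outcome again being a limit rather than a number.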

Compound 3, half-maximal effective concentration: > 30000 nM
Compound 3 was reported as a limit; the forecaster's own chance of this, stated with the estimate: 85%; the middle value sits exactly at the limit.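

In this assay compound 3 gives > 30000 nM and this is a limit of the assay, not a number. With compound 1, compound 2 and compound 3 all at that limit, no step among them can be read: the limit of > 30000 nM in this assay, at which 3 of the 3 values shown sit.

The compounds shown leave open whether any group on this amine nitrogen gives a measurable value in this assay at all.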